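Moving a Fluorine: What to Expect for Compound 3

This account rests on a few compounds, and the source may have more. Where it says the series, first, only, none or still open, it means among the compounds named here.

In an ADME assay on L02 cells (Homo sapiens) for cytotoxicity, read by MTT assay, with a stated time of 24 h (on this read-out lower numbers stand for stronger inhibition and higher numbers for weaker inhibition), compound 1 `CN1C/C(=C\c2ccc(C(F)(F)F)cc2)C(=O)/C(=C/c2ccccc2F)C1` gives 18600 nM and compound 2 `CN1C/C(=C\c2ccc(C#N)cc2)C(=O)/C(=C/c2ccccc2F)C1` gives 11000 nM as its value. For the measured compounds named here, these two numbers lie within the scatter of each other, so compound 2 does not stand apart from its only measured neighbour.

Compound 3 `CN1C/C(=C\c2ccc(F)cc2)C(=O)/C(=C/c2ccc(C#N)cc2)C1` is built from the same atoms as compound 2, joined differently: 4-fluorophenyl in place of 2-fluorophenyl on a double-bonded chain carbon bound to a double-bonded ring carbon. In plain terms, 4-fluorophenyl sits in place of 2-fluorophenyl on a double-bonded chain carbon bound to a double-bonded ring carbon.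

Going by the values given here, only one measured step is available as a guide. It is a 1.7-fold lower number from compound 1 to compound 2 (0.23 log units; within the scatter), with cyano in place of trifluoromethyl on an aromatic carbon, and it stays within the scatter. Among the compounds with values here, that step leaves the fluorine untouched, so it bears on this change only loosely, and no measured pair shows what moving the fluorine does. No shift beyond the scatter is therefore expected in this assay, though the uncertainty is wide.

The estimated step is a 1.1-fold higher number from compound 2 to compound 3 (0.04 log units; within the scatter) in this expectation. The estimate for compound 3 is 12000 nM with an expected range from 5000 nM to 28000 nM on this thin evidence.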

Compound 3, half-maximal inhibitory concentration: 20900 nM
Estimate against measurement, compound 3: 1.7-fold (0.24 log units) below; the range from low to high includes it.
By their numbers in this assay, from the lowest: compounds 2, 1 and 3 (each within the scatter of the next).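

Compound 3 gives the first measured view of this position, the double-bonded chain carbon bound to a double-bonded ring carbon: in this assay, 4-fluorophenyl in place of 2-fluorophenyl gives a 1.9-fold higher number from compound 2 to compound 3 (0.28 log units; within the scatter). The earlier pair changed only the other aromatic group, so it could not show that the fluorine can take either of these two places on this phenyl ring without the number leaving the usual scatter of repeat measurements. The three compounds now form a set in which each number lies within the scatter of the next, and no measurement shown offers an explanation for how close they stay.

As far as these compounds go, it remains open whether a different kind of group at this position, such as an amine or a carboxylic acid in place of the fluorine, would carry the number beyond the scatter. The compounds shown also share the same core with its methyl group, so they leave open what a longer chain in place of that methyl would do in this assay.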